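Carboxy for Bromo on the Benzoyl Ring of Compound 1

The compounds below may be only part of what the source reports. "The series", "measured", "known", "first", "only" and "open" are said of these compounds alone.

Measured compounds:
compound 1, `O=C(/C=C/c1ccc2c(c1)B(O)OC2)c1ccc(Br)cc1`, 4500 nM
compound 2, `O=C(/C=C/c1ccc2c(c1)B(O)OC2)c1cccc(F)c1`, 4800 nM
compound 3, `Cc1cccc(C(=O)/C=C/c2ccc3c(c2)B(O)OC3)c1`, 2900 nM

In a functional assay on SK-OV-3 cells (Homo sapiens) for cytotoxicity, read by MTT assay, with a stated time of 48 h (on this read-out higher numbers stand for weaker inhibition and lower numbers for stronger inhibition), compound 1 gives 4500 nM, the second highest of the three numbers. Its nearest neighbour is compound 2, with a 1.1-fold higher number from compound 1 to compound 2 (0.03 log units; within the scatter); the furthest is compound 3, with a 1.6-fold lower number from compound 1 to compound 3 (0.19 log units; within the scatter). Between compound 2 and compound 3 the difference is a 1.7-fold lower number from compound 2 to compound 3 (0.22 log units; within the scatter). All three steps lie within the scatter, so the three measured compounds cannot be ordered on these numbers.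

Compound 4, `O=C(O)c1ccc(C(=O)/C=C/c2ccc3c(c2)B(O)OC3)cc1`, is not yet measured. It differs from compound 1 as follows: carboxy in place of bromo on an aromatic carbon.

For the measured compounds named here, none of the measured steps covers a carboxy group; they exchange bromo, fluoro and methyl on the benzoyl ring, and each stayed within the scatter. The account therefore rests on the observation that substituent changes on this ring have so far moved the read-out little, while the carboxy group is a larger departure than any of them. Compound 4 is expected to give 7000 nM, in a range from 3000 nM to 20000 nM. The step this estimate means is a 1.6-fold higher number from compound 1 to compound 4 (0.19 log units; within the scatter), expected to be modestly upward but not certainly beyond the scatter.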

Compound 4, half-maximal inhibitory concentration: > 100000 nM
Compound 4: only a limit was reported (the forecaster's own chance of this, stated with the estimate: 15%); at least 14-fold (1.15 log units) between middle value and limit.
By their numbers in this assay, from the lowest: compounds 3, 1 and 2 (each within the scatter of the next). At a limit, above all of these: compound 4.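

Bromo, fluoro and methyl on this aromatic ring had all left the read-out within the scatter, which said nothing about how far that tolerance reaches. Carboxy, on an aromatic carbon para to a large group, is the one change shown that goes beyond the scatter, with an at least 22-fold higher number from compound 1 to compound 4 (1.34 log units; beyond the scatter). In this assay compound 4 gives > 100000 nM, which is a limit and not a number, and no property of the carboxy group is measured here, so the result shows only that this place does not accept every group: the limit of > 100000 nM in this assay, at which 1 of the 4 values shown sits.

What the compounds shown leave open is whether the change in read-out belongs to the carboxy group in particular or to any group bringing in a hydrogen-bond donor at this place, a question that a methyl ester, a primary amide, an amine or a hydroxy group there would address. They also leave open whether a carboxylic acid on the aromatic carbon that carries fluoro in compound 2 would give the same kind of result.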